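A few compounds are considered here, and "the series" means these few. Any claim that something is new, unique, unknown or untested is made for them only; others in the source may bear on it.

Measured compounds in a functional assay on MCF7 cells (Homo sapiens) for cytotoxicity, read by MTT assay, with a stated time of 72 h; on this read-out higher numbers stand for weaker inhibition and lower numbers for stronger inhibition:
compound 1, `CCOC(=O)c1cn(Cc2nnc(-c3cc(S(N)(=O)=O)c(SCc4ccccc4)cc3Cl)o2)nn1`, gives 150000 nM
compound 2, `CC(C)(O)c1cn(Cc2nnc(-c3cc(S(N)(=O)=O)c(SCc4ccccc4)cc3Cl)o2)nn1`, gives 168000 nM
compound 3, `NS(=O)(=O)c1cc(-c2nnc(Cn3cc(-c4ccccc4)nn3)o2)c(Cl)cc1SCc1ccccc1`, gives 170000 nM

All three share one core and differ only in the group carried on an aromatic carbon of the triazole. The steps between them are small: a 1.1-fold higher number from compound 1 to compound 2 (0.05 log units; within the scatter), a 1.1-fold higher number from compound 1 to compound 3 (0.05 log units; within the scatter) and a 1.0-fold higher number from compound 2 to compound 3 (0.01 log units; within the scatter), each within the scatter of this assay. Compound 3 therefore stands level with compounds 1 and 2; its number is not set apart from either.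

Compound 4, `COc1ccc(-c2cn(Cc3nnc(-c4cc(S(N)(=O)=O)c(SCc5ccccc5)cc4Cl)o3)nn2)cc1`, is built from compound 3 by methoxy in place of hydrogen on an aromatic carbon. Within the data shown here, none of the measured steps touches this phenyl; they exchange the whole substituent on the triazole carbon, and even those larger exchanges move the numbers by less than the scatter. Among the measured compounds shown here, the data give no step for adding a methoxy to the phenyl, so the expectation rests on the flatness seen across compounds 1, 2 and 3.

On that basis compound 4 is expected to show a step of about no change at the digits printed from compound 3 to compound 4 (within the scatter), which is no change beyond the scatter. The estimated value for compound 4 in this assay is 170000 nM, with a range from 80000 nM to 360000 nM.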

Compound 4, half-maximal inhibitory concentration: 1500000 nM
Compound 4: the middle estimate sits 8.8-fold (0.95 log units) below what was measured; the whole stated range lies below it.
By their numbers in this assay, from the lowest: compounds 1, 2 and 3 (each within the scatter of the next); then compound 4.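

In this assay, among these compounds, the flatness of the earlier compounds does not extend to the phenyl ring: a single methoxy in place of hydrogen, para to a large group, gives an 8.8-fold higher number from compound 3 to compound 4 (0.95 log units; beyond the scatter), a step beyond the scatter, whereas exchanging the whole substituent among ethoxycarbonyl, 1-hydroxy-1-methylethyl and phenyl left the numbers within the scatter of one another. The exchanges for 4-methoxyphenyl read the same way, with an 8.9-fold higher number from compound 2 to compound 4 (0.95 log units; beyond the scatter) and a 10-fold higher number from compound 1 to compound 4 (1.00 log units; beyond the scatter), so that compound 4 is the weakest of the four and this substituent is the only one shown that sets a compound apart. Nothing available here accounts for this loss of cytotoxic effect.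

From the compounds shown here alone, it remains open whether the step belongs to methoxy itself or would also come with a fluorine, a hydroxy, an amine or a longer chain such as ethoxy on the same aromatic carbon. Also open, going by these compounds, is whether methoxy would give a step of similar size on another carbon of that ring.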